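A few compounds are considered here, and "the series" means these few. Any claim that something is new, unique, unknown or untested is made for them only; others in the source may bear on it.

Series notes. Compound 1 `CC/C(C)=N\Nc1nc(-c2cccc([N+](=O)[O-])c2)cs1` gives 1040000 nM in a functional assay, with a stated time of 16 h; on this read-out higher numbers stand for weaker inhibition and lower numbers for stronger inhibition. Compound 2 `C/C(CC(C)C)=N/Nc1nc(-c2cccc([N+](=O)[O-])c2)cs1` gives 1050000 nM in this assay. Compound 3 `CCCC/C(C)=N\Nc1nc(-c2cccc([N+](=O)[O-])c2)cs1` gives 1060000 nM in this assay, and it stands level with the other two, since the steps of a 1.0-fold higher number from compound 1 to compound 3 (0.01 log units; within the scatter) and a 1.0-fold higher number from compound 2 to compound 3 (0.00 log units; within the scatter) both lie within the scatter. Compound 4 `CCCCCC/C(C)=N\Nc1nc(-c2cccc([N+](=O)[O-])c2)cs1` differs from compound 3 by ethyl in place of hydrogen on a saturated chain carbon, four bonds along the chain from a carbon with a double bond to nitrogen. The step that bears most directly on this change is a 1.0-fold higher number from compound 1 to compound 3 (0.01 log units; within the scatter), a chain extension that left the number flat; the branch change a 1.0-fold higher number from compound 1 to compound 2 (0.00 log units; within the scatter) was equally flat. No step beyond the scatter in this assay is therefore expected, in either direction, giving no change at the digits printed from compound 3 to compound 4 (within the scatter). Compound 4 is estimated at 1060000 nM, with a range from 550000 nM to 2100000 nM.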

Compound 4, half-maximal inhibitory concentration: 1110000 nM
The estimate for compound 4 lay 1.0-fold (0.02 log units) below the measured number, within the range that was stated.
By their numbers in this assay, from the lowest: compounds 1, 2, 3 and 4 (each within the scatter of the next).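

In this assay the ethyl in place of hydrogen, four bonds along the chain from the carbon with a double bond to nitrogen, gives a 1.0-fold higher number from compound 3 to compound 4 (0.02 log units; within the scatter) and so shows that the flat response reaches this further position. Among these compounds, the longer chain of compound 4 also stays level with the earlier compounds, with a 1.1-fold higher number from compound 1 to compound 4 (0.03 log units; within the scatter) and a 1.1-fold higher number from compound 2 to compound 4 (0.02 log units; within the scatter) as the wider comparisons. No evidence on hand bears on this flat response.

Going by these compounds, whether an amine or a carboxylic acid on this chain would move the number beyond the scatter remains open. So does the effect of a still longer chain.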